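The compounds below may be only part of what the source reports. "The series", "measured", "known", "first", "only" and "open" are said of these compounds alone.

Measured so far:
- compound 1, `O=C(O)Cc1sc(C(c2ccc(F)cc2)c2ccc(F)cc2)nc1-c1ccnc(Cl)c1`: 80%
- compound 2, `O=C(O)Cc1sc(C(c2ccc(F)cc2)c2ccc(F)cc2)nc1-c1cc(F)cc(F)c1`: 80%

In an in vitro functional assay on HEK285-7 cells for antagonist activity at prostaglandin D2 receptor 2 (Homo sapiens), read by BRET and beta-arrestin recruitment (a higher number here means a larger maximal response, a lower number a smaller maximal response), compound 1 reaches 80%, and compound 2 reaches 80%. Among the measured compounds shown here, the single measured step, no change at the digits printed from compound 1 to compound 2 (within the scatter), swapped one aromatic group on the shared core for another and left the maximal response unchanged. Compound 2 therefore stands level with compound 1 in this assay.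

Compound 3, `O=C(O)Cc1sc(C(c2ccc(F)cc2)c2ccc(F)cc2)nc1-c1ccco1`, has not been measured. It differs from compound 2 by furan-2-yl in place of 3,5-difluorophenyl on an aromatic carbon. For the measured compounds named here, the only step that bears on this position is the one from compound 1 to compound 2, which was within the scatter, so there is no evidence yet that this part of the molecule moves the maximal response. The expected step of a number 2 percentage points lower from compound 2 to compound 3 (within the scatter) is accordingly none beyond the scatter, though a smaller ring with an oxygen is a larger departure than the earlier swap. Compound 3 is estimated at 78% in this assay, within a range of 60% to 95%.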

Compound 3, largest response reached (reported as efficacy), in percent of the reference or control that the assay uses: 80%
Beside the measured number, compound 3's estimate is 2 percentage points below it; the range from low to high includes it.
By their numbers in this assay, from the lowest: compounds 1, 2 and 3 (each within the scatter of the next).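

The earlier compounds shown here carried only six-membered aromatic rings at this position, on an aromatic carbon next to the ring nitrogen. Furan-2-yl is a five-membered aromatic ring with an oxygen and brings a hydrogen-bond acceptor, yet in this assay it gives no change at the digits printed from compound 2 to compound 3 (within the scatter) and also no change at the digits printed from compound 1 to compound 3 (within the scatter), so the maximal response holds across a change in ring size and ring atoms. No measured property of these compounds is available to explain this flat result.

All three groups here are aromatic rings, so the compounds shown cannot say whether the maximal response would hold with an open chain such as n-butyl, a saturated ring such as piperidine, or a charged group such as a carboxylic acid at this position. A larger fused ring such as naphthyl also remains an open case.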